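The source may hold more compounds than are shown below. What is called first, only, known or untested is meant among the compounds shown, and "the series" means these compounds.

Measured so far (in a functional assay on MCF-A cells (Homo sapiens) for cytotoxicity; on this read-out higher numbers stand for weaker inhibition of growth and lower numbers for stronger inhibition of growth):
- Compound 1 `COc1ccc(C2=C(c3ccc(SC)cc3)CC3CCCN3C2=O)cc1O` gives 5000 nM
- Compound 2 `COc1ccc(C2=C(c3ccc(SC)cc3)CC3CCCN3C2=O)cc1Br` gives 6000 nM
- Compound 3 `COc1ccc(C2=C(c3ccc(SC)cc3)CC3CCCN3C2=O)cc1` gives 5000 nM

Compound 3 stands level with compound 1, and its gap to compound 2 lies within the scatter. Compound 4 `CSc1ccc(C2=C(c3ccc(SC)cc3)C(=O)N3CCCC3C2)cc1` carries methylsulfanyl in place of methoxy on an aromatic carbon. Among the compounds with values here, no measured step touches the methoxy group itself. Within the data shown here, the only steps available swap hydroxy, bromo and hydrogen on an aromatic carbon: a 1.2-fold higher number from compound 1 to compound 2 (0.08 log units; within the scatter), no change at the digits printed from compound 1 to compound 3 (within the scatter) and a 1.2-fold lower number from compound 2 to compound 3 (0.08 log units; within the scatter). All three stay within the scatter, so they offer only indirect evidence, and no step beyond the scatter is expected in this assay. The expected step is no change at the digits printed from compound 3 to compound 4 (within the scatter). Compound 4 is estimated at 5000 nM (expected range 2000 nM to 12000 nM).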

Compound 4, concentration for 50% growth inhibition: 8000 nM
Estimate against measurement, compound 4: 1.6-fold (0.20 log units) below; the measured number falls inside the stated range.
By their numbers in this assay, from the lowest: compounds 1, 3, 2 and 4 (each within the scatter of the next).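

In this assay, within the data shown here, methylsulfanyl in place of methoxy gives a 1.6-fold higher number from compound 3 to compound 4 (0.20 log units; within the scatter), the first step at this position para to a large group, and sulfur for oxygen here leaves the number within the scatter. The 4-(methylsulfanyl)phenyl compound also stays within the scatter of the two compounds with a further group on that ring, with a 1.3-fold higher number from compound 2 to compound 4 (0.12 log units; within the scatter) and a 1.6-fold higher number from compound 1 to compound 4 (0.20 log units; within the scatter). Nothing available explains the outcome of this swap. From the compounds shown here alone, whether an amine, a carboxylic acid or a longer alkoxy chain at this position would give a step beyond the scatter remains open.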